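The compounds below may be only part of what the source reports. "The series", "measured", "known", "first", "only" and "open" are said of these compounds alone.

In an ADME assay on microsomes from liver (Rattus norvegicus) for metabolic stability, read by LC-MS, tested at 1 uM (a higher number here means that the compound lasts longer, a lower number that the compound disappears faster), compound 1 `Nc1ncnc2c1c(Oc1cccc(Cl)c1)nn2CC1CCNC(=O)C1` is reported as > 1 h, which is a limit of the assay and not a number. This places compound 1 at the limit of > 1 h in this assay, at which 1 of the 2 values shown sits. In this assay, compound 2 `Nc1ncnc2c1c(Nc1cccc(Cl)c1)nn2CC1CCNCC1` gives a measured half-life of 0.333 h. The structural change leading to compound 3 `Nc1ncnc2c1c(Oc1cccc(Cl)c1)nn2CC1CCOCC1` places oxan-4-yl in place of 2-oxopiperidin-4-yl on a saturated chain carbon bound to an aromatic nitrogen. The core of compound 1 and its other substituent remain the same. Among the measured compounds shown here, no measured pair shows this change, and the limit for compound 1 leaves its true half-life open, so any forecast is loose. A small shortening of the half-life, not clearly beyond the scatter, is expected, with an at least 1.4-fold lower number from compound 1 to compound 3 (0.15 log units; that floor lies within the scatter) as the estimated step in this assay. For compound 3, the half-life is estimated at 0.7 h, with an expected range of 0.25 h to 1.5 h.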

Compound 3, half-life: 0.233 h
Compound 3: the middle estimate sits 3.0-fold (0.48 log units) above what was measured; measured number below the stated range.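

In this assay, among the compounds shown here, the change gives the first readable step at this position, a saturated chain carbon bound to an aromatic nitrogen: an at least 4.2-fold lower number from compound 1 to compound 3 (0.63 log units; beyond the scatter). With the core of compound 1 and its other substituent held the same, oxan-4-yl in place of 2-oxopiperidin-4-yl is enough to carry the half-life beyond the scatter, which compound 1 and compound 2 alone could not show. Compound 1 reads > 1 h, a limit and not a number, so the step is only a floor: the limit of > 1 h in this assay, at which 1 of the 3 values shown sits.

Whether the carbonyl or the ring nitrogen of 2-oxopiperidin-4-yl accounts for the difference stays open. As far as these compounds go, how a plain cyclohexyl ring or a longer chain ending in a carboxylic acid would behave at this place also remains open.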